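Aminomethyl series on the shared core: compound 4

This account rests on a few compounds, and the source may have more. Where it says the series, first, only, none or still open, it means among the compounds named here.

Working notes. Of the compounds shown here, three have been measured in an assay for inhibition of Tryptophan 2,3-dioxygenase (Homo sapiens), with stated times of 10 min and 60 min, tested at 100 uM (on this read-out higher numbers stand for a stronger effect at the one concentration tested and lower numbers for a weaker effect), so far. Compound 1 `FC(F)(F)c1cc(NC[C@H]2CCCN2)c2cn[nH]c2c1` gives 84% in this assay. Compound 2 `O=[N+]([O-])c1ccc2[nH]c(CNc3cc(C(F)(F)F)cc4[nH]ncc34)cc2c1` gives 69% and compound 3 `O=[N+]([O-])c1ccc(Cl)cc1CNc1cc(C(F)(F)F)cc2[nH]ncc12` gives 88% in this assay. Compound 1 thus stands second highest of the three; the gap to compound 3 lies within the scatter, while the gap to compound 2 lies beyond it, with compound 2 the lower of the two.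

The next compound, compound 4 `Nc1cccc(CNc2cc(C(F)(F)F)cc3[nH]ncc23)c1`, has not yet been measured. It differs from compound 1 in one place: 3-aminophenyl in place of pyrrolidin-2-yl on a saturated chain carbon bound to a nitrogen on an aromatic ring. No step between measured compounds with this change is available, so the expectation rests on the spread of the three numbers shown, all of which place a ring-bearing group on the same chain carbon. A step from compound 1 to compound 4 of about a number 6 percentage points lower from compound 1 to compound 4 (within the scatter) is expected, downward but not beyond the scatter. Compound 4 is estimated to give 78% in this assay, within a range from 55% to 95%.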

Compound 4, a percentage reported as inhibition, at one concentration (the size of the read-out at that concentration, not a potency): 89%
Estimate against measurement, compound 4: 11 percentage points below; measured number inside the range.
By their numbers in this assay, from the lowest: compound 2; then compounds 1, 3 and 4 (each within the scatter of the next).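

In this assay, the step on a saturated chain carbon bound to a nitrogen on an aromatic ring reads a number 5 percentage points higher from compound 1 to compound 4 (within the scatter): 3-aminophenyl in place of pyrrolidin-2-yl. This single-place comparison shows that a six-membered aromatic ring of carbon only can replace the five-membered non-aromatic ring here without a step beyond the scatter, and that the defined stereocentre of compound 1 is not needed to retain a read-out of this size at the one concentration tested. No measurement available here explains the result.

Whether the amine of 3-aminophenyl matters remains open, as the compounds shown include no unsubstituted phenyl or 3-carboxyphenyl group at this place. A longer chain between the ring and the nitrogen is also untested in the compounds shown, and a single-concentration read-out gives no potency for compound 1 or compound 4.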